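The source may hold more compounds than are shown below. What is called first, only, known or untested is meant among the compounds shown, and "the series" means these compounds.

Compound 3 `COc1nc(N)nc2c1c(-c1cc3ccccc3o1)cn2[C@@H]1O[C@H](CO)[C@@H](O)[C@H]1O` carries a 1-benzofuran-2-yl group on the shared core. Among the measured compounds shown here, in an ADME assay on BJ cells (Homo sapiens), read by MTT assay, with a stated time of 72 h (a higher number here means a weaker inhibitor, a lower number a stronger inhibitor), compound 3 gives 25600 nM as the lowest number of the three measured so far. Compound 1 `COc1nc(N)nc2c1c(-c1cccs1)cn2[C@@H]1O[C@H](CO)[C@@H](O)[C@H]1O` has thiophen-2-yl in that place and gives 99900 nM as its value. Compound 2 `COc1nc(N)nc2c1c(-c1ccccc1)cn2[C@@H]1O[C@H](CO)[C@@H](O)[C@H]1O` has phenyl there and gives > 100000 nM, which is a limit of the assay and not a number.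

The next structure is compound 4 `C#Cc1cn([C@@H]2O[C@H](CO)[C@@H](O)[C@H]2O)c2nc(N)nc(OC)c12`, in which ethynyl takes the place of 1-benzofuran-2-yl on an aromatic carbon: ethynyl in place of 1-benzofuran-2-yl on an aromatic carbon. All three measured steps change this same position. The first shows a 3.9-fold lower number from compound 1 to compound 3 (0.59 log units; beyond the scatter), the second at least 3.9-fold lower number from compound 2 to compound 3 (0.59 log units; beyond the scatter), and the third a number no lower from compound 1 to compound 2 (the limit leaves the size open). Among these three compounds, only the group with two rings has brought the number down, and no measured compound goes against that. For the measured compounds named here, no measured compound carries ethynyl, which has no ring, so the gain seen in the step to compound 3 is expected to be largely lost.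

The expected change is a 2.7-fold higher number from compound 3 to compound 4 (0.44 log units; beyond the scatter), a modest move to a higher number in this assay. For compound 4 the estimated value is 70000 nM, with an expected range from 20000 nM to 100000 nM.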

Compound 4, half-maximal inhibitory concentration: > 100000 nM
Compound 4 gave a limit, no number (the forecaster's own chance of this, stated with the estimate: 40%); middle value at least 1.4-fold (0.15 log units) from the limit.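

The result adds a group with no ring to this position, and the number does not come down with it: in this assay, ethynyl in place of 1-benzofuran-2-yl gives an at least 3.9-fold higher number from compound 3 to compound 4 (0.59 log units; beyond the scatter). Set against thiophen-2-yl, the same small group gives a number no lower from compound 1 to compound 4 (the limit leaves the size open), so among the four groups now shown, the only one that clearly lowers the number is still the one with two rings, and no compound shown goes against this. The step between compound 2 and compound 4 cannot be read, because both values sit at the same limit of the assay, so phenyl and ethynyl cannot be put in order: the limit of > 100000 nM in this assay, at which 2 of the 4 values shown sit.

Compound 3 is the only compound shown with two rings at this position, so it remains open whether the lower number goes with two rings in general or with 1-benzofuran-2-yl alone, and a group such as naphthalen-2-yl would test this. On these data alone, it is also open how a group with no ring other than ethynyl, such as an amine or a longer chain, would behave at this position.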